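Two amides of the shared core, and a third to come

A few compounds are considered here, and "the series" means these few. Any claim that something is new, unique, unknown or untested is made for them only; others in the source may bear on it.

Measured so far:
compound 1, `O=C(Nc1cccc([N+](=O)[O-])c1)C1CCCN(C(=O)c2cc(C(F)(F)F)cc(C(F)(F)F)c2)C1`: 9%
compound 2, `Cc1nc(-c2cccc(C(=O)N3CCCC(C(=O)Nc4ccc(Cl)cc4)C3)c2)no1`: 0%

Both compounds were tested in an ADME assay on PC-3 cells (Homo sapiens) for cytotoxicity, read by WST assay, tested at 100 uM; on this read-out higher numbers stand for more inhibition at the one concentration tested (going by the name of the read-out) and lower numbers for less inhibition. In this assay compound 1 gives 9%, and compound 2 gives 0%. These two numbers sit within the usual scatter of each other, so neither result stands apart from the other; both point to little inhibition of the cells at the concentration used.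

Compound 3, `O=C(Nc1ccc(Cl)cc1)C1CCCN(C(=O)c2cccc([N+](=O)[O-])c2)C1`, has not yet been measured in this assay. It differs from compound 2 in a single place: nitro in place of 5-methyl-1,2,4-oxadiazol-3-yl on an aromatic carbon. Within the data shown here, no step between measured compounds is known for this kind of change, so the expectation rests only on the two numbers seen. Since compound 1, which also carries a nitro group, gives 9%, and compound 2 gives 0%, a step in this assay of a size beyond the scatter is not expected in either direction. The expected step from compound 2 to compound 3 is a number 5 percentage points higher from compound 2 to compound 3 (within the scatter). Compound 3 is therefore estimated at 5%, with a range from 0% to 15%.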

Compound 3, a percentage reported as inhibition, at one concentration (the size of the read-out at that concentration, not a potency): 0%
Estimate against measurement, compound 3: 5 percentage points above; low and high end bracket the measured number.
By their numbers in this assay, from the lowest: compounds 2, 3 and 1 (each within the scatter of the next).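

In this assay, among these compounds, putting nitro in place of 5-methyl-1,2,4-oxadiazol-3-yl on an aromatic carbon, meta to a large group, gives no change at the digits printed from compound 2 to compound 3 (within the scatter) and this makes compound 2 and compound 3 the first pair here that differs in one place. The earlier compounds shown here differed in more than one place, so they could not speak for this position alone. Now it can be said that, in this one pair, a five-membered aromatic ring with 3 hetero atoms and a nitro group with no ring cannot be told apart on this read-out. No measurement at hand explains this outcome, so the result stands as an observation only.

On these data alone, whether an amine or a carboxylic acid at this same place would give a step beyond the usual scatter remains open, as does the effect of a longer chain there. A single pair also cannot show whether the same exchange would read the same way on a compound that differs elsewhere, or at a different concentration.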